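This account rests on a few compounds, and the source may have more. Where it says the series, first, only, none or still open, it means among the compounds named here.

Working notes on the series, read throughout in a functional assay on Jurkat cells (Homo sapiens) for inhibition, read by MTT assay, with a stated time of 72 h; on this read-out higher numbers stand for weaker inhibition of growth and lower numbers for stronger inhibition of growth. Compound 1 `COc1ccc(-c2nn(-c3ccccc3)c(/N=C/N(C)C)c2C=O)cc1` gives 12500 nM in this assay. Compound 2 `CN(C)/C=N/c1c(C=O)c(C(C)(C)C)nn1-c1ccccc1` gives 43500 nM in this assay. Going by the values given here, the one single-point step with two numbers is a 3.5-fold higher number from compound 1 to compound 2 (0.54 log units; beyond the scatter), a modest move that concerns a ring carbon away from the amidine and leaves the amidine untouched.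

Compound 3 `CN/C=N/c1cc(-c2ccccc2)nn1-c1ccccc1` is the case that sits at the limit of > 50000 nM in this assay, at which 1 of the 3 values shown sits. For compound 3 the value > 50000 nM in this assay is a limit of the assay and not a number. Compound 3 therefore stands at the weak end of the numbers shown, with no measured activity to move from.

Compound 4 `C/C(=N\c1cc(-c2ccccc2)nn1-c1ccccc1)N(C)C` differs from compound 3 by a group of 6 heavy atoms (4 carbon, 2 nitrogen; no ring) in place of a group of 4 heavy atoms (2 carbon, 2 nitrogen; no ring), on an aromatic carbon. Among the compounds with values here, no measured step bears on this exchange: the only step available, a 3.5-fold higher number from compound 1 to compound 2 (0.54 log units; beyond the scatter), changes a different position and a different kind of group, so it gives no direction for the amidine change. With compound 3 at a limit and nothing to calibrate the change, no move beyond the scatter is expected in this assay, and the most likely outcome is that compound 4 again returns only a limit. Compound 4 is estimated at 50000 nM in this assay, with a range from 20000 nM to 120000 nM. This estimate corresponds to an expected step of a number no higher from compound 3 to compound 4 (the limit leaves the size open).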

Compound 4, concentration for 50% growth inhibition: > 50000 nM
Compound 4: a limit, no number (the forecaster's own chance of this, stated with the estimate: 65%); the middle value sits exactly at the limit.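

No step can be read from compound 3 to compound 4 in this assay, since both return only a limit of the assay and not a number: the limit of > 50000 nM in this assay, at which 2 of the 4 values shown sit.

The compounds shown leave open whether a group of 6 heavy atoms in place of a group of 4 heavy atoms on this aromatic carbon changes growth inhibition at all.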